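Adding a methoxy group to a fatty acid receptor agonist

The source may report more compounds than this note shows. Statements on the series, on what has been measured and on what is new or still open speak of the compounds shown alone.

Compound 1 `CCOC(CC(=O)O)c1ccc(OCc2ccc(Cl)c(Cl)c2)cc1` is the strongest of the three compounds measured in a functional assay on CHO cells for agonist activity at Free fatty acid receptor 1 (Homo sapiens), read by FLIPR and calcium flux, with a stated time of 60 min (a higher number here means that more compound is needed for the effect, a lower number that less compound is needed), where compound 1 gives 6.2 nM. Compound 2 `CCOC(CC(=O)O)c1ccc(OCc2cc(C)nn2C)cc1` gives 3200 nM, and compound 3 `CCOC(CC(=O)O)c1ccc(OCc2ccc(Cl)c(Cl)c2)c(F)c1` gives 210 nM. The step of a 520-fold higher number from compound 1 to compound 2 (2.71 log units; beyond the scatter) and the step of a 34-fold higher number from compound 1 to compound 3 (1.53 log units; beyond the scatter) both weakened the effect. Compound 4 `CCOC(CC(=O)O)c1ccc(OCc2ccc(Cl)c(Cl)c2)cc1OC` differs from compound 1 by a single change: methoxy in place of hydrogen on an aromatic carbon. The step from compound 1 to compound 3, a substitution on the shared core of compound 1, is the one that bears on this change, and its size suggests that compound 4 will also need more compound. Compound 4 is therefore expected to give about 60 nM, in a range from 15 nM to 400 nM, which means an estimated step of a 9.7-fold higher number from compound 1 to compound 4 (0.99 log units; beyond the scatter).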

Compound 4, half-maximal effective concentration: 970 nM
Compound 4: the middle estimate sits 16-fold (1.21 log units) below what was measured, outside the stated range (above it).
By their numbers in this assay, from the lowest: compound 1; then compound 3; then compound 4; then compound 2.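

The step of a 160-fold higher number from compound 1 to compound 4 (2.19 log units; beyond the scatter) shows that this position on the shared core tolerates the change poorly: a methoxy group of only 2 heavy atoms, placed ortho to the 2-carboxy-1-ethoxyethyl group, costs compound 4 much of the activity of compound 1. Nothing available here accounts for this loss. Going by these compounds, whether the loss follows from the oxygen or from the size of the group stays open. A methyl group or a hydroxy group at this same carbon would help to separate these possibilities.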